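The source may hold more compounds than are shown below. What is called first, only, known or untested is meant among the compounds shown, and "the series" means these compounds.

Measured compounds in a functional assay on U-87MG ATCC cells for inhibition, with U-87 MG (Homo sapiens) as the target, read by MTT assay, with a stated time of 48 h; on this read-out higher numbers stand for weaker inhibition and lower numbers for stronger inhibition:

compound 1, `Fc1ccc(/C=N/Nc2nc(-c3ccc(C(F)(F)F)cc3)cs2)cc1F`, gives 29900 nM.
compound 2, `Fc1ccc(/C=N/Nc2nc(-c3ccccc3)cs2)cc1F`, gives only a limit of the assay, > 100000 nM.
compound 3, `COc1cc(/C=N/Nc2nc(-c3ccc(C(F)(F)F)cc3)cs2)cc(Br)c1OC`, gives 41000 nM.

Compound 1 and compound 2 differ by hydrogen in place of trifluoromethyl on an aromatic carbon. That change gives an at least 3.3-fold higher number from compound 1 to compound 2 (0.52 log units; beyond the scatter), and its size is bounded because compound 2 sits at the limit of > 100000 nM in this assay, at which 1 of the 3 values shown sits. Compound 3 stands near compound 1 in this assay, the gap between them lying within the scatter; how their two cores differ is not broken down here.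

Compound 4, `COc1cc(/C=N/Nc2nc(-c3ccccc3)cs2)cc(Br)c1OC`, has not been measured. It differs from compound 3 by hydrogen in place of trifluoromethyl on an aromatic carbon, which is the same change as from compound 1 to compound 2, at the same place. Since the measured step from compound 1 to compound 2 is at least modest and reaches the limit, compound 4 is expected to land at or beyond the same limit given an at least 3.3-fold higher number from compound 1 to compound 2 (0.52 log units; beyond the scatter) and (the limit of > 100000 nM in this assay, at which 1 of the 3 values shown sits). The step from compound 3 to compound 4 is expected to be about a 3.2-fold higher number from compound 3 to compound 4 (0.50 log units; beyond the scatter). Compound 4 is thus estimated at 130000 nM, between 60000 nM and 300000 nM, most likely reported as a limit.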

Compound 4, half-maximal inhibitory concentration: 74100 nM
Compound 4: middle estimate off by 1.8-fold (0.24 log units), on the high side, and the stated range covers the measured number.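

In this assay, the change from trifluoromethyl to hydrogen on the second core gives a 1.8-fold higher number from compound 3 to compound 4 (0.26 log units; within the scatter), so no real effect of the change can be claimed on this core. Set beside the first core, the comparison stays only partly readable: the same change on two cores in this assay, an at least 3.3-fold higher number (0.52 log units; beyond the scatter) from compound 1 to compound 2 and a 1.8-fold higher number (0.26 log units; within the scatter) from compound 3 to compound 4; the limit leaves it open whether they differ. The series therefore shows neither that the step carries over in size nor that the two cores respond differently, and the step on the first core has only a lower bound, as one end of it rests on a limit: the limit of > 100000 nM in this assay, at which 1 of the 4 values shown sits.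

The compounds shown leave open how other groups would read at this place on the aromatic ring, such as a chlorine, a nitrile, an amine or a carboxylic acid, since only trifluoromethyl and hydrogen appear there. They also leave open which of the substituents that separate the two cores, the fluorines on one side and the bromine and methoxy groups on the other, bears on the read-out.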